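The compounds below may be only part of what the source reports. "The series", "measured", "known", "first", "only" and "open" are said of these compounds alone.

Measured compounds:

Compound 1, `CCCCOc1ccc(-c2nc3ncccn3c2NCc2ccc(OC)cc2)cc1`: in a toxicity assay on A549 cells (Homo sapiens) for cytotoxicity, read by luminescence and CellTiter-Glo, with a stated time of 48 h (a lower number here means that less compound is tolerated, a higher number that more compound is tolerated), compound 1 gives 55000 nM.
Compound 2, `CCNC(=O)CCCOc1ccc(-c2nc3ncccn3c2NC2CCCCC2)cc1`: in this assay compound 2 reaches only the limit of the assay, > 100000 nM.
Compound 3, `O=C(O)CCCOc1ccc(-c2nc3ncccn3c2NC2CCCCC2)cc1`: in this assay compound 3 likewise reports only a limit, > 100000 nM.

Compound 3 therefore stands where no number is read at all; the same holds for compound 2, so that the limit of > 100000 nM in this assay, at which 2 of the 3 values shown sit, describes the bulk of what has been measured in the series. Within the data shown here, the one single-point step, a step that the two limits leave unreadable from compound 2 to compound 3, runs between two limits and gives no size. Among the measured compounds shown here, compound 1 is the only compound with a numerical value, and its difference from compound 3 covers more than one position, so it does not isolate any single change.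

The next compound, compound 4, is `CCOC(=O)CCCOc1ccc(-c2nc3ncccn3c2NC2CCCCC2)cc1`. It differs from compound 3 by ethyl in place of hydrogen on an oxygen next to a carbonyl group. For the measured compounds named here, no measured step bears on this change directly, and the available step is unreadable; the expectation is therefore no step beyond the scatter in this assay, and a high chance that compound 4 again reports only a limit. Compound 4 is estimated at 100000 nM, with a range from 40000 nM to 300000 nM, which means an expected step of a number no higher from compound 3 to compound 4 (the limit leaves the size open).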

Compound 4, half-maximal cytotoxic concentration: > 100000 nM
Compound 4 was reported as a limit (the forecaster's own chance of this, stated with the estimate: 70%); the middle value lies on the limit itself.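

Among these compounds, compound 2, compound 3 and compound 4 all report only limits in this assay, and no step among them can be read. Whether the hydroxy, ethoxy and ethylamino versions differ at all in cytotoxicity stays open, with most of the series resting on one limit: the limit of > 100000 nM in this assay, at which 3 of the 4 values shown sit.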